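Replacing methyl with 4-methylphenyl on a carbonyl carbon

The source may hold more compounds than are shown below. What is called first, only, known or untested is meant among the compounds shown, and "the series" means these compounds.

Of the compounds shown here, three sharing one core have been measured in a functional assay on A549 cells (Homo sapiens) for cytotoxicity, read by MTT assay, with a stated time of 72 h; on this read-out lower numbers stand for stronger inhibition and higher numbers for weaker inhibition. Compound 1 `O=C(COc1ccccc1)Nc1nnc(-c2cccc(O)c2O)s1` gives 10500 nM and compound 2 `O=C(Nc1nnc(-c2cccc(O)c2O)s1)c1ccccc1` gives 12300 nM. The difference between these two is a 1.2-fold higher number from compound 1 to compound 2 (0.07 log units; within the scatter), so they cannot be ranked. Compound 3 `CC(=O)Nc1nnc(-c2cccc(O)c2O)s1` gives 200000 nM, the highest number of the three and therefore the weakest inhibition in this small set.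

The next compound, compound 4 `Cc1ccc(C(=O)Nc2nnc(-c3cccc(O)c3O)s2)cc1`, changes one place in compound 3: 4-methylphenyl in place of methyl on a carbonyl carbon. In other words, it has 4-methylphenyl in place of methyl on a carbonyl carbon. Among the compounds with values here, two measured steps bear on this change. Replacing phenyl with methyl at this carbon gave a 16-fold higher number from compound 2 to compound 3 (1.21 log units; beyond the scatter), and removing phenoxy from the chain gave a 19-fold higher number from compound 1 to compound 3 (1.28 log units; beyond the scatter). Both are large, and read in reverse, they suggest that compound 4 should return to a much lower number. Within the data shown here, no measured compound shows what the extra methyl on the ring does, so the range stays wide. In this assay, the expected change is an 18-fold lower number from compound 3 to compound 4 (1.26 log units; beyond the scatter). For compound 4, the estimated value is 11000 nM, with an expected range from 4500 nM to 28000 nM.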

Compound 4, half-maximal inhibitory concentration: 11300 nM
Compound 4: the middle estimate sits 1.0-fold (0.01 log units) below what was measured; low and high end bracket the measured number.
By their numbers in this assay, from the lowest: compounds 1, 4 and 2 (each within the scatter of the next); then compound 3.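

In this assay, the change from methyl to 4-methylphenyl on the carbonyl carbon gives an 18-fold lower number from compound 3 to compound 4 (1.25 log units; beyond the scatter) and so extends the gain already seen with phenyl and phenoxymethyl to a third, differently substituted group at this position. The methyl added to the aromatic carbon makes no readable difference, with a 1.1-fold lower number from compound 2 to compound 4 (0.04 log units; within the scatter) in this assay, and 4-methylphenyl cannot be separated from phenoxymethyl either, with a 1.1-fold higher number from compound 1 to compound 4 (0.03 log units; within the scatter) on the same read-out, so compounds 1, 2 and 4 cannot be ranked and all that separates out here is compound 3, with its methyl on the carbonyl carbon, from the three compounds with a ring-bearing group there. No measurement is available to explain this gap between compound 3 and the other three compounds.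

All four compounds share the same core, so these results say nothing about changes made there, and the only substituent seen on the ring attached to the carbonyl carbon is a single methyl. From the compounds shown here alone, it remains open whether an amine or a carboxylic acid on that ring, a pyridine ring in its place, or a longer saturated chain on the carbonyl carbon would keep the number at this level or move it.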